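Trading Two Chlorines for Hydrogen on the Aryl Ketone

The source may hold more compounds than are shown below. What is called first, only, known or untested is meant among the compounds shown, and "the series" means these compounds.

Measured so far:
compound 1, `COc1cc(-c2cc(/C=C/C(C)=O)[nH]n2)cc(OC)c1OC`, 27300 nM 
compound 2, `COc1cc(-c2cc(/C=C/C(=O)c3ccc(Cl)c(Cl)c3)[nH]n2)cc(OC)c1OC`, 2100 nM 
compound 3, `COc1ccc(-c2cc(/C=C/C(=O)c3cc(OC)c(OC)c(OC)c3)[nH]n2)cc1OC`, 2000 nM 

In a functional assay on MDA-MB-231 cells (Homo sapiens) for inhibition, read by MTT assay, with a stated time of 48 h (on this read-out lower numbers stand for stronger inhibition and higher numbers for weaker inhibition), compound 2 gives 2100 nM, which places it second highest of the three numbers. Compound 3 sits within the scatter of compound 2, so the two cannot be told apart, while compound 1 stands far higher.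

Compound 4 is `COc1cc(-c2cc(/C=C/C(=O)c3ccccc3)[nH]n2)cc(OC)c1OC`. It differs from compound 2 in one place: phenyl in place of 3,4-dichlorophenyl on a carbonyl carbon. Within the data shown here, only one measured step touches this carbonyl carbon, the step of a 13-fold lower number from compound 1 to compound 2 (1.11 log units; beyond the scatter), which shows that a 3,4-dichlorophenyl group on the carbonyl gives a much lower number than a methyl group there. Compound 4 keeps an aromatic ring on the carbonyl, so a number far nearer to compound 2 than to compound 1 is expected; since the two chlorines are given up, a moderate rise, beyond the scatter but well short of the step to compound 1, is the expectation here. Compound 4 is therefore estimated at 5000 nM, with a range from 1500 nM to 15000 nM, meaning an expected step of a 2.4-fold higher number from compound 2 to compound 4 (0.38 log units; beyond the scatter).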

Compound 4, half-maximal inhibitory concentration: 2300 nM
For compound 4 the middle estimate is 2.2-fold (0.34 log units) above the measured one, within the range that was stated.
By their numbers in this assay, from the lowest: compounds 3, 2 and 4 (each within the scatter of the next); then compound 1.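

In this assay, taking both chlorines off the aryl ring on the carbonyl gives a 1.1-fold higher number from compound 2 to compound 4 (0.04 log units; within the scatter), a change within the scatter, so at this position the 3,4-dichlorophenyl and the plain phenyl cannot be told apart. The large drop seen earlier, a 13-fold lower number from compound 1 to compound 2 (1.11 log units; beyond the scatter), therefore does not depend on the chlorines: a plain phenyl in place of methyl on the same carbonyl carbon gives a 12-fold lower number from compound 1 to compound 4 (1.07 log units; beyond the scatter), so for these three compounds the large difference lies between methyl and either aromatic ring, not between the two rings. No measurement is available to explain why the numbers fall this way.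

As far as these compounds go, these compounds cover only methyl, phenyl and 3,4-dichlorophenyl on this carbonyl carbon, so it remains open whether a longer chain such as hexyl, or a saturated ring such as cyclohexyl, would stay near methyl or reach the level of the two aryl compounds. From the compounds shown here alone, it is also open whether a phenyl carrying an amine or a carboxylic acid would stay as indifferent to the added group as the two chlorines suggest.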